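Swapping nitro for methoxycarbonyl in a cytotoxicity series

This account rests on a few compounds, and the source may have more. Where it says the series, first, only, none or still open, it means among the compounds named here.

Measured in an ADME assay on HL-60 cells (Homo sapiens) for cytotoxicity, read by MTT assay, with a stated time of 24 h; a lower number here means a stronger inhibitor, a higher number a weaker inhibitor:
- Compound 1 `CC(C)CN(C)Cc1ccc(C2=CCCN(C)C2)cc1`: > 50000 nM, a limit
- Compound 2 `COc1ccc(CN(C)Cc2ccc(C3=CCCN(C)C3)cc2)cc1`: > 50000 nM, a limit
- Compound 3 `CN1CCC=C(c2ccc(CN(C)Cc3ccc([N+](=O)[O-])cc3)cc2)C1`: 28000 nM

Only one of these three results is an actual number, and compound 3 holds it at 28000 nM. Compound 1 and compound 2 give only (the limit of > 50000 nM in this assay, at which 2 of the 3 values shown sit). A limit says that the assay did not reach a half-maximal effect, so it cannot be used as a precise value.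

Compound 4 `COC(=O)c1ccc(CN(C)Cc2ccc(C3=CCCN(C)C3)cc2)cc1` has not yet been measured. It carries methoxycarbonyl in place of nitro on an aromatic carbon, para to a large group (methoxycarbonyl in place of nitro on an aromatic carbon).

The most relevant measured change concerns the same nitro group, and it is an at least 1.7-fold lower number from compound 2 to compound 3 (0.25 log units; that floor lies within the scatter). This gives no clear sign that swapping that group moves the result by much. The other measured change, a step that the two limits leave unreadable from compound 1 to compound 2, lies elsewhere in the structure and has no readable size, so it offers no guidance here.

No change beyond the usual scatter is therefore expected. The expected step is a 1.3-fold higher number from compound 3 to compound 4 (0.10 log units; within the scatter). For compound 4, the estimate is 35000 nM, with an expected range from 15000 nM to 60000 nM.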

Compound 4, half-maximal inhibitory concentration: > 50000 nM
Compound 4: no number, only a limit; the forecaster's own chance of this, stated with the estimate: 40%; middle value at least 1.4-fold (0.15 log units) from the limit.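

At this position, on an aromatic carbon para to a large group, there are now two results that can be set side by side in this assay, and the move from nitro to methoxycarbonyl gives an at least 1.7-fold higher number from compound 3 to compound 4 (0.25 log units; that floor lies within the scatter). Only a floor is known for this step, so the true change could be small or much larger, and the result does not establish that nitro matters here, although it remains the only group shown at this position with an actual number. The step from compound 2 to compound 4 joins two limits and cannot be read, and the series now rests mostly on a single limit: the limit of > 50000 nM in this assay, at which 3 of the 4 values shown sit.

For the compounds shown here, it remains unknown whether nitro truly differs from methoxy or methoxycarbonyl by more than the usual scatter, as compound 3 is the only compound with a number. The compounds shown also leave open how an amine or a carboxylic acid at this position would read in this assay, and whether any group here could give a number clearly apart from that of compound 3.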